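Replacing 5-fluoro-2-hydroxyphenyl with carbamoyloxy

This account rests on a few compounds, and the source may have more. Where it says the series, first, only, none or still open, it means among the compounds named here.

- Compound 1 `COC1=CC(=O)c2c(c(COC(=O)c3ccc(F)cc3)c(C)n2C)C1=O`: 27000 nM
- Compound 2 `COC1=CC(=O)c2c(c(Cc3cc(F)ccc3O)c(C)n2C)C1=O`: 200000 nM

In a functional assay on V79-379A cells (Cricetulus griseus) for cytotoxicity, read by MTT assay, in the presence of a further agent that is not named here (a higher number here means a weaker inhibitor, a lower number a stronger inhibitor), compound 2 stands at the top of the two numbers with 200000 nM, which makes it the weaker inhibitor. Compound 1 gives 27000 nM, and this gap lies beyond the scatter.

Compound 3 `COC1=CC(=O)c2c(c(COC(N)=O)c(C)n2C)C1=O` has not yet been measured. It is compound 2 with carbamoyloxy in place of 5-fluoro-2-hydroxyphenyl on a saturated chain carbon bound to an aromatic carbon.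

Going by the values given here, no measured pair isolates this change, so the expectation rests on thin evidence. Compound 1 also lacks the 5-fluoro-2-hydroxyphenyl group and gives 27000 nM, which points towards a lower number. In this assay, the expected change, beyond the scatter, is a 5.7-fold lower number from compound 2 to compound 3 (0.76 log units; beyond the scatter). For compound 3 the estimated value is 35000 nM, with an expected range of 6000 nM to 150000 nM.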

Compound 3, half-maximal inhibitory concentration: 25000 nM
Compound 3: middle estimate off by 1.4-fold (0.15 log units), on the high side; low and high end bracket the measured number.
By their numbers in this assay, from the lowest: compounds 3 and 1 (each within the scatter of the next); then compound 2.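

In this assay, putting carbamoyloxy in place of 5-fluoro-2-hydroxyphenyl on this saturated chain carbon gives an 8.0-fold lower number from compound 2 to compound 3 (0.90 log units; beyond the scatter) and so isolates this swap in a single measured pair. Putting amino in place of 4-fluorophenyl on the carbonyl carbon gives a 1.1-fold lower number from compound 1 to compound 3 (0.03 log units; within the scatter) and so leaves the two compounds indistinguishable, which means this assay does not separate these two groups at that carbon. Nothing available here explains either result.

Still open, on these data alone, is whether an amine or a carboxylic acid on the same saturated chain carbon would fall with compound 1 and compound 3 or with compound 2. As far as these compounds go, it is also open whether a methylamino group in place of amino on the carbonyl carbon would shift the number at all.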